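A new ring on the sulfonyl sulfur

A few compounds are considered here, and "the series" means these few. Any claim that something is new, unique, unknown or untested is made for them only; others in the source may bear on it.

Of the compounds shown here, three sharing one core have been measured in an ADME assay on microsomes (Homo sapiens) for metabolic stability; on this read-out higher numbers stand for fast clearance and lower numbers for slow clearance. Compound 1 `Cc1cc(C(F)(F)F)c2cccc(OCc3c(Cl)ccc(S(=O)(=O)N4CCC[C@H]4CO)c3Cl)c2n1` gives 250 mL/min/kg, compound 2 `COC[C@@H]1CCCN1S(=O)(=O)c1ccc(Cl)c(COc2cccc3c(C(F)(F)F)cc(C)nc23)c1Cl` gives 450 mL/min/kg, and compound 3 `Cc1cc(C(F)(F)F)c2cccc(OCc3c(Cl)ccc(S(=O)(=O)N4CCCC4)c3Cl)c2n1` gives 233 mL/min/kg. Compound 3, which carries a plain pyrrolidin-1-yl group, stands level with the other two, as every gap among the three lies within the usual scatter of repeat measurements.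

Compound 4 `Cc1cc(C(F)(F)F)c2cccc(OCc3c(Cl)ccc(S(=O)(=O)N4CCC(C#N)CC4)c3Cl)c2n1` has 4-cyanopiperidin-1-yl in place of pyrrolidin-1-yl on a sulfonyl sulfur.

The closest evidence comes from steps that alter the same ring. Taking away hydroxymethyl gives a 1.1-fold lower number from compound 1 to compound 3 (0.03 log units; within the scatter), and taking away methoxymethyl gives a 1.9-fold lower number from compound 2 to compound 3 (0.29 log units; within the scatter). Placing methyl on the oxygen of the side chain gives a 1.8-fold higher number from compound 1 to compound 2 (0.26 log units; within the scatter). All three stay within the scatter, but none of them changes the ring size or brings in a nitrile, so they are only an indirect guide. On this evidence, no step beyond the scatter is expected in this assay, and no direction is favoured. The estimated change is a 1.0-fold higher number from compound 3 to compound 4 (0.01 log units; within the scatter). For compound 4 the estimated clearance is 240 mL/min/kg, with an expected range from 120 mL/min/kg to 480 mL/min/kg.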

Compound 4, clearance: 433 mL/min/kg
Estimate against measurement, compound 4: 1.8-fold (0.26 log units) below; the measured number falls inside the stated range.
By their numbers in this assay, from the lowest: compounds 3, 1, 4 and 2 (each within the scatter of the next).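

In this assay, the step from a plain pyrrolidin-1-yl group to 4-cyanopiperidin-1-yl on the sulfonyl sulfur is a 1.9-fold higher number from compound 3 to compound 4 (0.27 log units; within the scatter), so a six-membered ring carrying a nitrile is not told apart from the five-membered ring by this read-out. The comparisons with the two substituted rings read the same way, with a 1.0-fold lower number from compound 2 to compound 4 (0.02 log units; within the scatter) and a 1.7-fold higher number from compound 1 to compound 4 (0.24 log units; within the scatter), which means that this position has now taken a change of ring size, and not only a change of side chain, without any step beyond the scatter. No measurement at hand explains where these numbers fall.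

Ring size and nitrile enter together in compound 4, so the part each one plays stays open, and a plain piperidin-1-yl group on the sulfonyl sulfur would separate the two. Also open, as far as these compounds go, is whether any group at this position, such as morpholin-4-yl or a piperidine ring bearing a carboxylic acid, would move the number in this assay beyond the scatter.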